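Trimming a Piperidine Side Chain Down to a Carbamoyl

The source may hold more compounds than are shown below. What is called first, only, known or untested is meant among the compounds shown, and "the series" means these compounds.

Of the compounds shown here, three built on a shared core have been tested in an ADME assay on L02 cells (Homo sapiens) for cytotoxicity, read by MTT assay, with a stated time of 48 h; a lower number here means a stronger inhibitor, a higher number a weaker inhibitor. Compound 1 `CN1CCN(C[C@H]2CN(c3ccc(-n4cc(-c5ccccn5)cn4)c(F)c3)C(=O)O2)CC1` gives 70 ug/mL. Compound 2 `COC(=O)CC1CCN(C[C@H]2CN(c3ccc(-n4cc(-c5ccccn5)cn4)c(F)c3)C(=O)O2)CC1` returns only > 400 ug/mL, which is a limit of the assay rather than a number. Compound 3 `CCNC(=O)NC[C@H]1CN(c2ccc(-n3cc(-c4ccccn4)cn3)c(F)c2)C(=O)O1` likewise returns > 400 ug/mL, again a limit. Compound 2 therefore stands at the upper boundary of what has been recorded, the point noted as the limit of > 400 ug/mL in this assay, at which 2 of the 3 values shown sit. The measured steps are an at least 5.7-fold higher number from compound 1 to compound 2 (0.75 log units; beyond the scatter) and an at least 5.7-fold higher number from compound 1 to compound 3 (0.75 log units; beyond the scatter), while a step that the two limits leave unreadable from compound 2 to compound 3.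

Compound 4 `NC(=O)[C@H]1CN(c2ccc(-n3cc(-c4ccccn4)cn3)c(F)c2)C(=O)O1` differs from compound 2 by carbamoyl in place of (4-((methoxycarbonyl)methyl)piperidin-1-yl)methyl on a saturated ring carbon. Of the measured steps, the two exchanges of the 4-methylpiperazin-1-yl group bear on it most, and both ended at the limit, as does the unreadable step between compound 2 and compound 3. Compound 4 is therefore expected to remain at or near that boundary, so the step of a number no higher from compound 2 to compound 4 (the limit leaves the size open) is estimated to show no change beyond the scatter. Compound 4 is estimated at 400 ug/mL, within 150 ug/mL to 800 ug/mL.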

Compound 4, half-maximal inhibitory concentration: 119 ug/mL
Compound 4: the middle estimate sits 3.4-fold (0.53 log units) above what was measured; the whole stated range lies above it.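

In this assay, the small carbamoyl on the saturated ring carbon next to the ring oxygen brings the read-out down from the limit, with an at least 3.3-fold lower number from compound 2 to compound 4 (0.52 log units; beyond the scatter) and an at least 3.3-fold lower number from compound 3 to compound 4 (0.52 log units; beyond the scatter). Losing the 4-methylpiperazin-1-yl group therefore does not by itself carry this position to the limit, as the earlier exchanges might have suggested; compound 4 goes against that pattern, and the change to carbamoyl gives a 1.7-fold higher number from compound 1 to compound 4 (0.23 log units; within the scatter). The values of compound 2 and compound 3 remain limits and not numbers, so both steps down to compound 4 have a minimum size only: the limit of > 400 ug/mL in this assay, at which 2 of the 4 values shown sit.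

Going by these compounds, their full size therefore stays open. Also open, on these data alone, is whether an aminomethyl group, a carboxylic acid or a longer chain ending in a carbamoyl at this ring carbon would stay level with compound 4 or return to the limit.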